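The source may report more compounds than this note shows. Statements on the series, on what has been measured and on what is new or still open speak of the compounds shown alone.

The shared core of this small set carries a propylsulfanyl group, a benzyl group and a hydrazone arm whose aryl end is varied. Compound 1 `CCCSc1nc(N/N=C/c2ccc(C)cc2)c2nnn(Cc3ccccc3)c2n1` carries a 4-methylphenyl at that end, compound 2 `CCCSc1nc(N/N=C/c2ccc([N+](=O)[O-])cc2)c2nnn(Cc3ccccc3)c2n1` a 4-nitrophenyl, and compound 3 `CCCSc1nc(N/N=C/c2cccc(Cl)c2)c2nnn(Cc3ccccc3)c2n1` a 3-chlorophenyl. In a functional assay on MCF7 cells (Homo sapiens) for antiproliferative activity, read by MTT assay, with a stated time of 72 h (a lower number here means a stronger inhibitor, a higher number a weaker inhibitor), compound 2 gives 11000 nM. Compound 1 reaches only a limit of this assay, > 64000 nM. Compound 3 likewise reaches only a limit, > 64000 nM. Of the three steps among them, an at least 5.8-fold lower number from compound 1 to compound 2 (0.76 log units; beyond the scatter) and an at least 5.8-fold higher number from compound 2 to compound 3 (0.76 log units; beyond the scatter) are readable, while a step that the two limits leave unreadable from compound 1 to compound 3 is not, since (the limit of > 64000 nM in this assay, at which 2 of the 3 values shown sit).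

Compound 4 `CCCSc1nc(N/N=C/c2ccccc2)c2nnn(Cc3ccccc3)c2n1` has a plain phenyl in place of the 3-chlorophenyl of compound 3: hydrogen in place of chloro on an aromatic carbon. Going by the values given here, no measured step in this set involves a chloro substituent alone, so none speaks directly to this change. Among the compounds with values here, the only compound with a number rather than a limit, compound 2, owes its number to a nitro group, which compound 4 does not carry. Compound 4 is therefore expected to remain near the limit where compound 3 sits, with a step that the limit leaves unreadable from compound 3 to compound 4 as the expected step, most likely nothing beyond the scatter. The estimate for compound 4 in this assay is 70000 nM, in a range from 30000 nM to 200000 nM.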

Compound 4, half-maximal inhibitory concentration: > 64000 nM
Compound 4: only a limit was reported (the forecaster's own chance of this, stated with the estimate: 75%); the middle value does not contradict the limit.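

Taking the chloro group off the aromatic ring does not lift the compound out of the limit in this assay, so a plain phenyl at the end of the hydrazone arm is no better placed to give a number than the 3-chlorophenyl. Compound 4 also supplies the simplest comparison so far for the nitro group, since hydrogen in place of nitro gives an at least 5.8-fold higher number from compound 2 to compound 4 (0.76 log units; beyond the scatter), and compound 2 now stands apart from an unsubstituted ring as well as from the rings with methyl or chloro. The steps among compound 1, compound 3 and compound 4 cannot be read, since all three sit at one limit and any real differences among them stay hidden: the limit of > 64000 nM in this assay, at which 3 of the 4 values shown sit.

From the compounds shown here alone, whether the chloro group changes anything at all therefore stays open, and so does how much weaker than compound 2 these three compounds really are. Also open, going by these compounds, is whether the number depends on nitro itself, or whether an amine, a nitrile or a carboxylic acid at the same place on the ring would also bring the value inside the range of the assay.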